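The source may report more compounds than this note shows. Statements on the series, on what has been measured and on what is new or still open speak of the compounds shown alone.

In a functional assay on NCI-H522 cells (Homo sapiens) for cytotoxicity, with a stated time of 3 days (a lower number here means a stronger inhibitor, a higher number a weaker inhibitor), compound 1 (`C=Cc1nc2ccccc2s1`) gives > 40000 nM, which is a limit of the assay. On these data alone, compound 2 (`CC#Cc1nc2ccccc2s1`) gives > 40000 nM, again only a limit and not a number, so its true position is unknown. Compound 3 (`Ic1nc2ccccc2s1`) carries iodo in place of prop-1-yn-1-yl on an aromatic carbon. For the measured compounds named here, the one measured step bearing on this change is a step that the two limits leave unreadable from compound 1 to compound 2, and it gives no size to carry over. It concerns a different exchange at the same place. Going by the values given here, the series so far shows (the limit of > 40000 nM in this assay, at which 2 of the 2 values shown sit). With compound 2 at > 40000 nM, no readable step in this assay can be forecast, and no direction is expected. The expected step is a number no higher from compound 2 to compound 3 (the limit leaves the size open). For compound 3 the estimated value is 40000 nM, with an expected range from 15000 nM to 80000 nM.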

Compound 3, half-maximal inhibitory concentration: > 40000 nM
Compound 3 ended at the assay's limit (the forecaster's own chance of this, stated with the estimate: 75%); the middle value sits exactly at the limit.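

In this assay compound 3 gives > 40000 nM, a limit and not a number. No step among compound 1, compound 2 and compound 3 can be read: the limit of > 40000 nM in this assay, at which 3 of the 3 values shown sit.

On these data alone, how vinyl, prop-1-yn-1-yl and iodo on the shared core rank against one another in this assay stays open.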